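Relocating the Pyridine Methyls: Expected Clearance for Compound 4

The compounds below may be only part of what the source reports. "The series", "measured", "known", "first", "only" and "open" are said of these compounds alone.

Measured compounds:
Compound 1, `CC[C@H](C)[C@@H]1C(=O)N[C@H](C2Cc3ccccc3C2)C(=O)N1[C@@H](C(=O)N(C)C)c1cc(C)cnc1C`: in an in vitro ADME assay on microsomes from liver (Canis lupus familiaris) for metabolic stability (a higher number here means faster removal of the compound, a lower number slower removal), compound 1 gives 2 mL.min-1.g-1.
Compound 2, `CC[C@H](C)[C@@H]1C(=O)N[C@H](C2Cc3ccccc3C2)C(=O)N1[C@@H](C(=O)N1CCOCC1)c1ccc(C)nc1`: in this assay compound 2 gives 2 mL.min-1.g-1.
Compound 3, `CC[C@H](C)[C@@H]1C(=O)N[C@H](C2Cc3ccccc3C2)C(=O)N1[C@@H](C(=O)NC)c1cc(C)cnc1C`: in this assay compound 3 gives 3 mL.min-1.g-1.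

Compound 3 carries the largest of the three numbers, but its gap to compound 1 and its gap to compound 2 both lie within the scatter, so the three compounds cannot be told apart on these figures. Within the data shown here, the only measured step, a 1.5-fold higher number from compound 1 to compound 3 (0.18 log units; within the scatter), replaced methyl with hydrogen on an amide-type nitrogen and stayed within the scatter.

Compound 4, `CC[C@H](C)[C@@H]1C(=O)N[C@H](C2Cc3ccccc3C2)C(=O)N1[C@@H](C(=O)NC)c1cnc(C)cc1C`, differs from compound 3 by 4,6-dimethylpyridin-3-yl in place of 2,5-dimethylpyridin-3-yl on a saturated chain carbon bound to an amide-type nitrogen in a ring and a carbonyl carbon. Among the measured compounds shown here, no measured step touches the substitution pattern of that ring, so the one available step is only a loose guide: it shows that a small change elsewhere on this core left this assay essentially unmoved.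

Compound 4 is therefore expected to give about 3 mL.min-1.g-1, somewhere between 1.5 mL.min-1.g-1 and 6 mL.min-1.g-1. That estimate means an expected step of no change at the digits printed from compound 3 to compound 4 (within the scatter), not beyond the scatter.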

Compound 4, intrinsic clearance in microsomes: 4 mL.min-1.g-1
Estimate against measurement, compound 4: 1.3-fold (0.12 log units) below; low and high end bracket the measured number.
By their numbers in this assay, from the lowest: compounds 1, 2, 3 and 4 (each within the scatter of the next).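

Exchanging 2,5-dimethylpyridin-3-yl for 4,6-dimethylpyridin-3-yl, on a saturated chain carbon bound to an amide-type nitrogen in a ring and a carbonyl carbon, gave a 1.3-fold higher number from compound 3 to compound 4 (0.12 log units; within the scatter) in this assay. This is the first step among these compounds that reads this position directly, and it shows that this rearrangement of the same atoms leaves compound 4 indistinguishable from compound 3 in this read-out. No supporting measurement bears on why this is so.

Every compound shown keeps at least one methyl on this ring, so it remains open whether a carboxylic acid, an amine or a longer chain there would also stay within the scatter. On these data alone, it is also open whether the same exchange would read alike with the amide carried by compound 1.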